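Carbamoyl for ethyl at the cytotoxicity limit

The source may hold more compounds than are shown below. What is called first, only, known or untested is meant among the compounds shown, and "the series" means these compounds.

In an ADME assay on BJ cells (Homo sapiens) for cytotoxicity, with a stated time of 72 h (on this read-out higher numbers stand for an effect only at larger amounts of compound and lower numbers for an effect already at smaller amounts), compound 1 `CCc1ccc(NC(=O)Nc2cc(C)nc3ccccc23)cc1` gives > 25000 nM as a limit of the assay and not a number. Compound 2 `Cc1cc(NC(=O)Nc2ccc3[nH]cnc3c2)c2ccccc2n1` gives > 25000 nM and this too is a limit. Compound 1 therefore stands at the limit of > 25000 nM in this assay, at which 2 of the 2 values shown sit, and no number places it more exactly.

Compound 3 `Cc1cc(NC(=O)Nc2ccc(C(N)=O)cc2)c2ccccc2n1` keeps the core of compound 1 and changes one group (carbamoyl in place of ethyl on an aromatic carbon) with carbamoyl in place of ethyl on an aromatic carbon, para to a large group. Among the measured compounds shown here, no measured step between compounds gives a size for this change. The expectation rests on compound 1 with its > 25000 nM as a limit. Expected here is a number no higher from compound 1 to compound 3 (the limit leaves the size open) and so no step beyond the scatter in this assay in either direction. The estimate for compound 3 is 25000 nM and is expected to fall within 12000 nM to 50000 nM on this read-out.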

Compound 3, half-maximal effective concentration: > 25000 nM
Compound 3 ended at the assay's limit; the forecaster's own chance of this, stated with the estimate: 85%; the middle value lies on the limit itself.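

For compound 1 and compound 3, this assay gives limits and not numbers, so no step between them can be read: the limit of > 25000 nM in this assay, at which 3 of the 3 values shown sit.

The compounds shown leave open at what concentration any of them would affect these cells, and whether carbamoyl in place of ethyl on an aromatic carbon alters that.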